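This account rests on a few compounds, and the source may have more. Where it says the series, first, only, none or still open, it means among the compounds named here.

Measured compounds in a physicochemical assay for lipophilicity; on this read-out lower numbers stand for lower lipophilicity and higher numbers for higher lipophilicity:
compound 1, `CCCCCCCCCCCCCCCCC/C=C1\CC(CO)(COC(C)=O)OC1=O`, 7.11
compound 2, `CCCCCCCCCCCCCCCCC/C=C1/CC(CO)(COC(C)=O)OC1=O`, 7.11
compound 3, `O=C1CCCCCCCCCCCCCCCCCC/C=C2\CC(CO)(CO1)OC2=O`, 5.81

Compound 1 stands level with compound 2 at the digits shown, the two together at the top of the three numbers; compound 3 gives 5.81, which lies beyond the scatter below compound 1. Among the compounds with values here, the only step measured between compounds differing in one place is no change at the digits printed from compound 1 to compound 2 (within the scatter), and that pair differs in the drawing of a double bond, as noted in the fact that one of compounds 1 and 2 is drawn with a defined configuration and the other without, at the place where they differ, not in the chain.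

Compound 4, `CCCCCCCCCCCCC/C=C1\CC(CO)(COC(C)=O)OC1=O`, is still to be measured in this assay. Against compound 1 the change is hydrogen in place of butyl on a saturated chain carbon, ten or more bonds along the chain from a double-bonded chain carbon. Within the data shown here, no measured step shortens or lengthens the saturated chain, so nothing among the three compounds gives a direct size for this change; the step from compound 1 to compound 2 leaves the chain untouched and offers no guide. Removal of butyl from a saturated chain is expected to lower the partition coefficient, so the step from compound 1 to compound 4 is estimated as a number 2.01 log units lower from compound 1 to compound 4 (beyond the scatter). On that basis compound 4 is expected to give 5.1 in this assay, within a range of 4.5 to 5.7.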

Compound 4, partition coefficient: 5.36
The estimate for compound 4 lay 0.26 log units below the measured number; the range from low to high includes it.
By their numbers in this assay, from the lowest: compound 4; then compound 3; then compounds 1 and 2 (each within the scatter of the next).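

In this assay, within the data shown here, the saturated chain is the first place where a change in one place gives a step that can be sized: with hydrogen in place of butyl on a saturated chain carbon, the read-out gives a number 1.75 log units lower from compound 1 to compound 4 (beyond the scatter). Among these compounds, the only earlier step between compounds differing in one place, no change at the digits printed from compound 1 to compound 2 (within the scatter), left the chain untouched, so the far part of the chain now stands as a position where the read-out moves, while the drawing of the double bond has so far left it unmoved. Nothing on record gives a cause for this step, as the available information concerns only the double bond and not the chain.

One step at one chain length leaves open whether the number follows chain length evenly, or whether a longer chain, or hydrogen in place of methyl or ethyl, would fit the same size of step. Also open, as far as these compounds go, are whether the same shortening gives a step of this size on compound 2, and how a carboxylic acid or an amine at this chain position would read.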